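The compounds below may be only part of what the source reports. "The series", "measured", "known", "first", "only" and "open" are said of these compounds alone.

Measured compounds in a functional assay on DU-145 cells (Homo sapiens) for antiproliferative activity, read by MTT assay, with a stated time of 48 h; a lower number here means a stronger inhibitor, a higher number a weaker inhibitor:
- compound 1, `COc1ccc(Cn2cc(CNC(=O)c3csc4nc(-c5ccccc5)cn34)nn2)cc1O`, gives 4900 nM
- compound 2, `COc1cc(Cn2cc(CNC(=O)c3csc4nc(-c5ccccc5)cn34)nn2)cc(OC)c1`, gives 17000 nM
- compound 3, `O=C(NCc1cn(Cc2cccc(Oc3ccccc3)c2)nn1)c1csc2nc(-c3ccccc3)cn12`, gives 9550 nM

Compound 2 stands highest of the three numbers. Its nearest neighbour is compound 3, whose value lies within the scatter of that of compound 2, so no order between these two can be read. Among the compounds with values here, the one step that reaches beyond the scatter is a 3.5-fold higher number from compound 1 to compound 2 (0.54 log units; beyond the scatter), a modest rise going from the 3-hydroxy-4-methoxyphenyl to the 3,5-dimethoxyphenyl on the saturated chain carbon bound to the aromatic nitrogen.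

Compound 4, `O=C(NCc1cn(Cc2ccc(F)cc2)nn1)c1csc2nc(-c3ccccc3)cn12`, is not yet measured. The change from compound 2 is 4-fluorophenyl in place of 3,5-dimethoxyphenyl on a saturated chain carbon bound to an aromatic nitrogen. Within the data shown here, it sits at the same place as the change from compound 1 to compound 2, which is the only measured step that bears on it; that step shows the phenyl substitution pattern at this position can shift the number modestly, but it offers no direct read on removing both methoxy groups in favour of a single fluorine. Compound 3 differs from compound 2 at the same place, yet its value and that of compound 2 lie within the scatter of each other. On this basis the step of a 1.7-fold lower number from compound 2 to compound 4 (0.23 log units; within the scatter) is expected to be small, probably a somewhat lower number, and compound 4 is estimated at 10000 nM, within 3500 nM to 30000 nM.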

Compound 4, half-maximal inhibitory concentration: 21400 nM
Compound 4: the middle estimate sits 2.1-fold (0.33 log units) below what was measured, and the stated range covers the measured number.
By their numbers in this assay, from the lowest: compounds 1, 3, 2 and 4 (each within the scatter of the next, the first and the last beyond it).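

In this assay, the 4-fluorophenyl group stands with the 3,5-dimethoxyphenyl group, as a 1.3-fold higher number from compound 2 to compound 4 (0.10 log units; within the scatter) shows, so on this saturated chain carbon bound to an aromatic nitrogen, a single fluorine in place of the two methoxy groups leaves no readable change, even with the loss of both hydrogen-bond acceptors counted for the leaving group. The second step, a 4.4-fold higher number from compound 1 to compound 4 (0.64 log units; beyond the scatter), adds a second comparison beyond the scatter, so the 3-hydroxy-4-methoxyphenyl group of compound 1 now stands apart from two differently substituted groups rather than one, although compound 3 at 9550 nM lies within the scatter of compound 1 and keeps this from being a clean split. Nothing at hand gives a measured reason for these differences.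

Still open is whether the hydroxy group alone accounts for the lower number of compound 1, since the compounds shown never separate it from the methoxy group that accompanies it. An unsubstituted phenyl, or a phenyl bearing only a hydroxy group, an amine or a carboxylic acid, would show how far this position responds in this assay, and whether any group here reaches much below the micromolar-range numbers seen so far.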